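Swapping the nitrophenyl for a chlorophenyl in compound 4

The compounds below may be only part of what the source reports. "The series", "measured", "known", "first", "only" and "open" are said of these compounds alone.

Three measured compounds share one core and differ only in the aryl group on the amine nitrogen in a ring. Compound 1 `COC(=O)C1=C(C)N=C(C)/C(=C(/O)OC)C1c1cccc(N/C(=N/CCNC2CCN(c3ccccc3)CC2)NC#N)c1` gives 10 nM in an assay on SK-N-MC cells for inhibition of Neuropeptide Y receptor type 1 (Homo sapiens); on this read-out lower numbers stand for stronger inhibition and higher numbers for weaker inhibition. Compound 2 `COC(=O)C1=C(C)N=C(C)/C(=C(/O)OC)C1c1cccc(N/C(=N/CCNC2CCN(c3ccccc3[N+](=O)[O-])CC2)NC#N)c1` gives 4 nM in this assay, and compound 3 `COC(=O)C1=C(C)N=C(C)/C(=C(/O)OC)C1c1cccc(N/C(=N/CCNC2CCN(c3ccccc3O)CC2)NC#N)c1` gives 5 nM. Among the compounds with values here, compound 2 holds the lowest of the three numbers, though the step of a 1.3-fold higher number from compound 2 to compound 3 (0.10 log units; within the scatter) lies within the scatter, as does a 2.0-fold lower number from compound 1 to compound 3 (0.30 log units; within the scatter); only the step of a 2.5-fold lower number from compound 1 to compound 2 (0.40 log units; beyond the scatter) stands beyond it.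

Compound 4 `COC(=O)C1=C(C)N=C(C)/C(=C(/O)OC)C1c1cccc(N/C(=N/CCNC2CCN(c3cccc(Cl)c3)CC2)NC#N)c1` is not yet measured. It differs from compound 2 by 3-chlorophenyl in place of 2-nitrophenyl on an amine nitrogen in a ring. Within the data shown here, this removes the nitro whose introduction gave a 2.5-fold lower number from compound 1 to compound 2 (0.40 log units; beyond the scatter) and places a chlorine at a position for which no measured step exists. Among the measured compounds shown here, the only step bearing on the change is thus the reverse of a 2.5-fold lower number from compound 1 to compound 2 (0.40 log units; beyond the scatter), pointing to a modest rise in this assay. The expected step is a 2.5-fold higher number from compound 2 to compound 4 (0.40 log units; beyond the scatter). Compound 4 is therefore estimated at 10 nM, with a range from 4 nM to 25 nM.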

Compound 4, half-maximal inhibitory concentration: 8 nM
For compound 4 the middle estimate is 1.3-fold (0.10 log units) above the measured one, within the range that was stated.
By their numbers in this assay, from the lowest: compounds 2, 3, 4 and 1 (each within the scatter of the next, the first and the last beyond it).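

In this assay, 3-chlorophenyl cannot be told apart from two of the earlier aryl groups, with a 2.0-fold higher number from compound 2 to compound 4 (0.30 log units; within the scatter) and a 1.6-fold higher number from compound 3 to compound 4 (0.20 log units; within the scatter), and chloro in place of hydrogen also stays within the scatter, with a 1.3-fold lower number from compound 1 to compound 4 (0.10 log units; within the scatter). On this amine nitrogen in a ring, the nitro group of compound 2 can therefore give way to a group with no hydrogen-bond acceptors without a step that exceeds the scatter. No measurement at hand explains why these aryl groups read so much alike.

The compounds shown leave open whether the place of the chlorine matters, since 2-chlorophenyl is not among them. They also do not show how this series would respond to a carboxylic acid or an amine on the phenyl ring.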